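The compounds below may be only part of what the source reports. "The series", "measured", "known", "first", "only" and "open" are said of these compounds alone.

Measured so far in this series:
compound 1, `COc1ccc([C@H]2CC(C)(O)[C@@H]3CC[C@@H](C)C[C@H]3O2)cc1` — 689000 nM
compound 2, `COc1ccc([C@H]2CC(C)(O)[C@@H]3CC[C@@H](C)C[C@H]3O2)c(OC)c1` — > 937000 nM
compound 3, `COc1cc([C@H]2CC(C)(F)[C@@H]3CC[C@@H](C)C[C@H]3O2)ccc1O` — 642000 nM

In an ADME assay on MDCK cells (Canis lupus familiaris) for cytotoxicity, read by MTT assay, with a stated time of 48 h (a higher number here means that more compound is tolerated, a lower number that less compound is tolerated), compound 1 gives 689000 nM. Compound 2 reaches only a limit of the assay, > 937000 nM. The change methoxy in place of hydrogen on an aromatic carbon thus yields an at least 1.3-fold higher number from compound 1 to compound 2 (0.13 log units; that floor lies within the scatter), a floor set by the limit of > 937000 nM in this assay, at which 1 of the 3 values shown sits. Compound 3 gives 642000 nM in this assay; how its core differs from the core of compound 1 is not broken down here.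

Compound 4, `COc1cc([C@H]2CC(C)(F)[C@@H]3CC[C@@H](C)C[C@H]3O2)cc(OC)c1O`, is not yet measured in this assay. Its change from compound 3, (methoxy in place of hydrogen on an aromatic carbon), is the same kind of change as that from compound 1 to compound 2, but the surroundings differ: here the place is ortho to a hydroxy group and meta to a large group, whereas in compound 2 it is ortho to a large group. Resting on an at least 1.3-fold higher number from compound 1 to compound 2 (0.13 log units; that floor lies within the scatter), the step expected for compound 4 is a 1.2-fold higher number from compound 3 to compound 4 (0.10 log units; within the scatter). For compound 4 the estimate is 800000 nM, with a range from 450000 nM to 1400000 nM, and a real chance that only a limit is reported.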

Compound 4, half-maximal cytotoxic concentration: 158000 nM
Estimate against measurement, compound 4: 5.1-fold (0.70 log units) above; the whole stated range lies above it.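

Methoxy in place of hydrogen on an aromatic carbon gives a 4.1-fold lower number from compound 3 to compound 4 (0.61 log units; beyond the scatter) in this assay. Carried from one core to the other, this change does not keep its step: the same change on two cores in this assay, an at least 1.3-fold higher number (0.13 log units; that floor lies within the scatter) from compound 1 to compound 2 and a 4.1-fold lower number (0.61 log units; beyond the scatter) from compound 3 to compound 4, at least 5.5-fold (0.74 log units) apart, beyond the scatter of two such steps. The earlier step is only a floor, and the data do not show whether the core or the place of the entering methoxy sets the two steps apart: the limit of > 937000 nM in this assay, at which 1 of the 4 values shown sits.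

Open, from the compounds shown here alone, is whether methoxy ortho to a large group on the core of compound 3 would give a step like the earlier one in this assay. Also open, going by these compounds, is how an amine or a carboxylic acid in place of the methoxy, ortho to a hydroxy group, would read there.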